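A few compounds are considered here, and "the series" means these few. Any claim that something is new, unique, unknown or untested is made for them only; others in the source may bear on it.

Of the compounds shown here, three have been read so far in a functional assay on DU-145 cells (Homo sapiens) for inhibition, read by trypan blue exclusion, with a stated time of 96 h; a higher number here means a weaker inhibitor of growth, a lower number a stronger inhibitor of growth. Compound 1 (`Cc1cc(C)cc(/C=C(/SCc2ccc(F)cc2)C(=O)c2ccc(Br)cc2)c1`) gives 10000 nM, compound 3 (`COc1ccc(/C=C(/Sc2ccc(C)cc2)C(=O)c2ccc(Br)cc2)cc1`) gives 50000 nM, and compound 2 (`O=C(/C(=C\c1ccccc1OCc1ccccc1)SCc1ccc(F)cc1)c1ccc(Cl)cc1`) gives 1000 nM, the lowest number of the three and beyond the scatter from both others. Compound 4 (`Cc1ccc(CS(=O)(=O)/C(=C/c2ccccc2OCc2ccccc2)C(=O)c2ccc(Cl)cc2)cc1`) is unmeasured and differs from compound 2 as follows: (4-methylbenzyl)sulfonyl in place of (4-fluorobenzyl)sulfanyl on a double-bonded chain carbon bound to a carbonyl carbon and a double-bonded chain carbon. In words, (4-methylbenzyl)sulfonyl stands in place of (4-fluorobenzyl)sulfanyl on a double-bonded chain carbon bound to a carbonyl carbon and a double-bonded chain carbon. Among the compounds with values here, no measured pair isolates this change, so the direction is tentative. A modest expected move towards a lower number is a 2.0-fold lower number from compound 2 to compound 4 (0.30 log units; within the scatter), and no change beyond the scatter remains possible. In this assay the estimated value for compound 4 is 500 nM, with an expected range of 50 nM to 5000 nM.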

Compound 4, concentration for 50% growth inhibition: 1000 nM
Compound 4: the middle estimate sits 2.0-fold (0.30 log units) below what was measured; the range from low to high includes it.
By their numbers in this assay, from the lowest: compounds 2 and 4 (each within the scatter of the next); then compound 1; then compound 3.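

In this assay the double-bonded chain carbon bound to a carbonyl carbon and a double-bonded chain carbon carries (4-methylbenzyl)sulfonyl in place of (4-fluorobenzyl)sulfanyl with no change at the digits printed from compound 2 to compound 4 (within the scatter), so this position tolerates the larger group in this series. Sulfanyl to sulfonyl and fluorine to methyl change together, so neither can be read alone, and opposing contributions cannot be excluded. No measurement at hand explains the result. Open, on these data alone, is how a (4-fluorobenzyl)sulfonyl group compares, and whether an amine or a carboxylic acid at this position would keep the value.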